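This account rests on a few compounds, and the source may have more. Where it says the series, first, only, none or still open, it means among the compounds named here.

Compound 1 `COC(=O)c1ccc(NCc2cncn2Cc2cccc([N+](=O)[O-])c2)cc1-c1ccccc1`: > 10000 nM
Compound 2 `COC(=O)c1ccc(NCc2cncn2Cc2ccccc2Br)cc1-c1ccccc1`: 10000 nM

Among the measured compounds shown here, in a toxicity assay on NIH3T3 cells (Mus musculus) for cytotoxicity, read by resazurin assay (on this read-out higher numbers stand for an effect only at larger amounts of compound and lower numbers for an effect already at smaller amounts), compound 2 gives 10000 nM, the only true number so far. Compound 1 gives > 10000 nM, which is a limit of the assay and not a number. For the measured compounds named here, the one measured step is a number no higher from compound 1 to compound 2 (the limit leaves the size open), so it gives no usable size, and it involves a different swap of groups.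

Compound 3 `COC(=O)c1ccc(NCc2cncn2Cc2ccc(Br)cc2)cc1-c1ccccc1` keeps the core of compound 2 and changes one group: 4-bromophenyl in place of 2-bromophenyl on a saturated chain carbon bound to an aromatic nitrogen. This puts 4-bromophenyl in place of 2-bromophenyl on a saturated chain carbon bound to an aromatic nitrogen.

With only compound 2 at 10000 nM as a guide, no change beyond the scatter is expected in this assay. The expected size is no change at the digits printed from compound 2 to compound 3 (within the scatter). For compound 3 the estimate is 10000 nM, with an expected range of 4000 nM to 20000 nM.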

Compound 3, half-maximal effective concentration: > 10000 nM
Compound 3: a limit, no number (the forecaster's own chance of this, stated with the estimate: 55%); the middle value lies on the limit itself.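

In this assay compound 3 gives > 10000 nM, which is a limit of the assay and not a number. Exchanging 2-bromophenyl for 4-bromophenyl keeps the same atoms and gives a number no lower from compound 2 to compound 3 (the limit leaves the size open), so this new placing of the bromine does not bring the effect to smaller amounts of compound. The size of this step and the step between the two compounds with limits cannot be read, and the data for this position crowd at one end of the scale: the limit of > 10000 nM in this assay, at which 2 of the 3 values shown sit.

Still open, from the compounds shown here alone, is whether an amine or a carboxylic acid on the phenyl ring, or a longer chain at this position, would bring the effect to clearly smaller amounts in this assay. Also open, going by these compounds, is how much larger the amounts needed for an effect would be for the compounds that reach the limit.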